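The source may hold more compounds than are shown below. What is called first, only, known or untested is meant among the compounds shown, and "the series" means these compounds.

Compound 1 `CC(C)(C)c1cc2[nH]nc(N)c2c(=O)[nH]1`: -15%
Compound 2 `CC(=O)Nc1nn(C)c2cc(-c3ccc(N4CCN(C)CC4)cc3)[nH]c(=O)c12`: 13%
Compound 3 `Nc1c2c(=O)[nH]c(-c3ccccc3)cc2nn1-c1ccccc1`: 23%

In an assay on isolated protein for inhibition of serine/threonine-protein kinase D2 (Homo sapiens), read by mobility shift assay, tested at 30 uM (a higher number here means more inhibition at the concentration tested (going by the name of the read-out), a lower number less inhibition), compound 3 gives 23%, the top of the three numbers shown. Compound 2 sits within the usual scatter of it, so the two cannot be told apart; compound 1 lies beyond the scatter below compound 3, the only clear gap among the three. Compound 4 `COc1ccc(-c2cc3nn(-c4ccccc4)c(N)c3c(=O)[nH]2)cc1` differs from compound 3 in one place: methoxy in place of hydrogen on an aromatic carbon. Going by the values given here, no pair of measured compounds shows what such a change does here, and nothing in the three numbers points in one direction. The step of a number 2 percentage points higher from compound 3 to compound 4 (within the scatter) is therefore expected to stay within the scatter, with no clear direction. Compound 4 is expected to give 25%, estimated between 5% and 45%.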

Compound 4, a percentage reported as inhibition, at one concentration (the size of the read-out at that concentration, not a potency): 28%
Estimate against measurement, compound 4: 3 percentage points below; the range from low to high includes it.
By their numbers in this assay, from the lowest: compound 1; then compounds 2, 3 and 4 (each within the scatter of the next, the first and the last beyond it).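

Going by these compounds alone, the phenyl to 4-methoxyphenyl change is the first comparison in one place in this assay and gives a number 5 percentage points higher from compound 3 to compound 4 (within the scatter). So methoxy can stand on this aromatic carbon, para to a large group, but compound 3 and compound 4 cannot be told apart. No measurement shown offers an explanation for this result. As far as these compounds go, it remains open whether an amine or a carboxylic acid at this place, or a longer chain in place of methoxy, would give a step beyond the scatter.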